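From fluoro to trifluoromethyl in a growth assay

The source may hold more compounds than are shown below. What is called first, only, known or untested is meant among the compounds shown, and "the series" means these compounds.

Measured in a functional assay on COLO 205 cells (Homo sapiens) for inhibition, read by sulforhodamine B assay; a lower number here means a stronger inhibitor of growth, a higher number a weaker inhibitor of growth:
- Compound 1 `Cc1ccc2[nH]c(-c3ccc(-c4ccc(-c5ccc(N(C)C)cc5)cc4)cc3)nc2c1` gives 9210 nM
- Compound 2 `Oc1cccc2[nH]c(-c3ccc(-c4ccc(-c5ccc(C(F)(F)F)cc5)cc4)cc3)nc12` gives 3410 nM
- Compound 3 `Cc1ccc2[nH]c(-c3ccc(-c4ccc(-c5ccc(F)cc5)cc4)cc3)nc2c1` gives 100000 nM

Compound 3 has the highest of these three numbers, which puts it at the weak end of this small set. Compound 4 `Cc1ccc2[nH]c(-c3ccc(-c4ccc(-c5ccc(C(F)(F)F)cc5)cc4)cc3)nc2c1` has not been measured yet. It keeps the core and methyl group of compound 3 and carries trifluoromethyl in place of fluoro on an aromatic carbon, para to a large group: trifluoromethyl in place of fluoro on an aromatic carbon.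

Within the data shown here, no measured pair shows this exact swap, so two indirect clues must serve. The first is an 11-fold higher number from compound 1 to compound 3 (1.04 log units; beyond the scatter), which shows that changing the group at this same place on the same core can shift the number by a large amount. The second is compound 2, which has trifluoromethyl at this place on a differently substituted core and gives 3410 nM. Together they suggest a large step towards a lower number in this assay, though the uncertainty is wide.

The expected change is a 13-fold lower number from compound 3 to compound 4 (1.10 log units; beyond the scatter). Compound 4 is estimated at 8000 nM, with an expected range of 2000 nM to 40000 nM.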

Compound 4, concentration for 50% growth inhibition: 30600 nM
Beside the measured number, compound 4's estimate is 3.8-fold (0.58 log units) below it, and the stated range covers the measured number.
By their numbers in this assay, from the lowest: compound 2; then compound 1; then compound 4; then compound 3.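

In this assay, the swap now has a direct measure on the shared core: a 3.3-fold lower number from compound 3 to compound 4 (0.51 log units; beyond the scatter). Trifluoromethyl therefore gives a lower number than fluoro at this place, though the step is only modest. On the same core, dimethylamino still gives the lowest number of the three groups, as shown by a 3.3-fold higher number from compound 1 to compound 4 (0.52 log units; beyond the scatter), so the order from lowest to highest runs dimethylamino, trifluoromethyl, fluoro. With trifluoromethyl held fixed, a change on the core alone also moves the number, as shown by a 9.0-fold higher number from compound 2 to compound 4 (0.95 log units; beyond the scatter), so the outcome at this place cannot be read without regard to the core that carries it.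

On these data alone, it remains open whether a carboxylic acid, a primary amine or a longer chain at this place would fit into this order, and whether the same order holds on the core of compound 2. Nothing available here explains why the three groups rank as they do.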